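Trimming the Methylsulfanyl Group from Compound 1

The source may hold more compounds than are shown below. What is called first, only, known or untested is meant among the compounds shown, and "the series" means these compounds.

Compound 1 `CSc1ccc(C(=O)Nc2nn[nH]n2)nc1` was tested in a functional assay on the whole organism for inhibition, with Rattus norvegicus as the target, at a dose of 10 mg/kg by the oral route (on this read-out higher numbers stand for a stronger effect at the one dose given and lower numbers for a weaker effect), and in that setting compound 1 gives 29%. For the measured compounds named here, that is the higher of the two numbers measured so far. Its nearest neighbour, compound 2 `CCCCc1cccc(C(=O)Nc2nn[nH]n2)n1`, gives 18% in this assay, and the gap between the two lies beyond the usual scatter of repeated measurements. Going by the values given here, no two measured compounds differ in only one place, so no single-point step has yet been observed.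

Compound 3 `O=C(Nc1nn[nH]n1)c1ccccn1` has not been measured. It differs from compound 1 in one way: hydrogen in place of methylsulfanyl on an aromatic carbon. Among the compounds with values here, with only two measured values and no comparable step to lean on, a modest downward move in this assay seems the most likely outcome, though a change within the scatter is quite possible. Compound 3 is expected to give 20%, with a likely range from 5% to 38%, which corresponds to an estimated step of a number 9 percentage points lower from compound 1 to compound 3 (within the scatter).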

Compound 3, a percentage reported as inhibition, in the whole organism at one dose (the size of the read-out at that dose, not a potency): 35%
Compound 3: middle estimate off by 15 percentage points, on the low side; the range from low to high includes it.
By their numbers in this assay, from the lowest: compound 2; then compounds 1 and 3 (each within the scatter of the next).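

In this assay, the methylsulfanyl group on this carbon, two atoms from the ring nitrogen, turns out not to be needed for the effect seen at this one dose: putting hydrogen in its place gives a number 6 percentage points higher from compound 1 to compound 3 (within the scatter) and so leaves the read-out indistinguishable. The exchange of butyl for hydrogen on an aromatic carbon counts for more, with a number 17 percentage points higher from compound 2 to compound 3 (beyond the scatter), so the bare compound 3 keeps pace with compound 1 and stands clear of compound 2. No measurement available here accounts for either step.

On these data alone, whether any group on this carbon can raise the read-out beyond that of hydrogen stays open, since an amine or a carboxylic acid there could move it either way. A single dose also leaves the potency of these compounds unknown.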